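Swapping fluoro for methyl on the aromatic ring

The compounds below may be only part of what the source reports. "The series", "measured", "known", "first", "only" and "open" are said of these compounds alone.

- Compound 1 `COc1cc(C(=O)c2sc(-c3ccccc3Cl)cc2N)cc(OC)c1OC`: 17 nM
- Compound 2 `COc1cc(C(=O)c2sc(-c3ccsc3)cc2N)cc(OC)c1OC`: 8.8 nM
- Compound 3 `COc1cc(C(=O)c2sc(-c3ccc(F)cc3)cc2N)cc(OC)c1OC`: 12 nM

All three values come from a functional assay on MOLT-4 cells (Homo sapiens) for antiproliferative activity; on this read-out lower numbers stand for stronger inhibition and higher numbers for weaker inhibition. On these numbers, compound 3 cannot be told apart from the other two compounds. The unmeasured compound 4 `COc1cc(C(=O)c2sc(-c3ccc(C)cc3)cc2N)cc(OC)c1OC` keeps the shared core and has methyl in place of fluoro on an aromatic carbon, para to a large group (methyl in place of fluoro on an aromatic carbon).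

Going by the values given here, no measured step makes this exact swap. The closest evidence comes from three steps that exchange the whole aromatic group: a 1.9-fold lower number from compound 1 to compound 2 (0.29 log units; within the scatter), a 1.4-fold lower number from compound 1 to compound 3 (0.15 log units; within the scatter) and a 1.4-fold higher number from compound 2 to compound 3 (0.13 log units; within the scatter). All three lie within the scatter, so no step beyond the scatter is expected in either direction. The expected result is no change at the digits printed from compound 3 to compound 4 (within the scatter). For compound 4, the estimated value is 12 nM, within an expected range of 5 nM to 30 nM.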

Compound 4, half-maximal inhibitory concentration: 16 nM
Compound 4: middle estimate off by 1.3-fold (0.12 log units), on the low side; low and high end bracket the measured number.
By their numbers in this assay, from the lowest: compounds 2, 3, 4 and 1 (each within the scatter of the next).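

In this assay, methyl in place of fluoro on this aromatic carbon gives a 1.3-fold higher number from compound 3 to compound 4 (0.12 log units; within the scatter), so the two groups cannot be told apart here. Compound 4 also sits within the scatter of the other two compounds, with a 1.8-fold higher number from compound 2 to compound 4 (0.26 log units; within the scatter) and a 1.1-fold lower number from compound 1 to compound 4 (0.03 log units; within the scatter), so all four aromatic groups shown give numbers that cannot be separated. Nothing available explains this result. As far as these compounds go, whether an amine or a carboxylic acid on this carbon would also stay within the scatter remains open.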